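A few compounds are considered here, and "the series" means these few. Any claim that something is new, unique, unknown or untested is made for them only; others in the source may bear on it.

Series notes, adenosine receptor binding. Compound 1 `COc1cccc(CNc2nc(N)c3nc(-c4cccs4)sc3n2)c1` and compound 2 `COc1ccccc1CNc1nc(N)c2nc(-c3cccs3)sc2n1` share one core and differ only in the aryl group carried on a saturated chain carbon bound to a nitrogen on an aromatic ring. In an assay on CHO cells for displacement of a labelled ligand from adenosine receptor A1 (Homo sapiens), read by scintillation counting, with a stated time of 90 min (a lower number here means a stronger inhibitor, a higher number a weaker inhibitor), compound 1 gives 37 nM, while compound 2 gives 17.3 nM. Among the measured compounds shown here, the single measured step, a 2.1-fold lower number from compound 1 to compound 2 (0.33 log units; beyond the scatter), places compound 2 at the lowest number of the two, with compound 1 as its only neighbour.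

Compound 3 `Nc1nc(NCc2cccs2)nc2sc(-c3cccs3)nc12` is not yet measured. Relative to compound 2 the change is thiophen-2-yl in place of 2-methoxyphenyl on a saturated chain carbon bound to a nitrogen on an aromatic ring. For the measured compounds named here, the one measured step concerns only the position of a methoxy group on the phenyl ring, not the exchange of that ring for a smaller aromatic ring; it was modest in size and does not bear directly on the present change. Going by the values given here, no measured pair therefore informs this step, and an expectation can only be set close to compound 2 with wide margins. For compound 3 the expected step is a 1.7-fold higher number from compound 2 to compound 3 (0.24 log units; within the scatter), a small weakening that may well lie within the scatter. The estimate for compound 3 in this assay is 30 nM, with a range from 10 nM to 90 nM.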

Compound 3, inhibition constant: 73 nM
Compound 3: middle estimate off by 2.4-fold (0.39 log units), on the low side; the measured number falls inside the stated range.
By their numbers in this assay, from the lowest: compound 2; then compounds 1 and 3 (each within the scatter of the next).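

In this assay, the group on a saturated chain carbon bound to a nitrogen on an aromatic ring can now be judged as a whole ring exchange, not only as a shift of the methoxy group: thiophen-2-yl in place of 2-methoxyphenyl gives a 4.2-fold higher number from compound 2 to compound 3 (0.63 log units; beyond the scatter). The same exchange made against 3-methoxyphenyl gives a 2.0-fold higher number from compound 1 to compound 3 (0.30 log units; within the scatter), so thiophen-2-yl and 3-methoxyphenyl are not separated here, and among the three groups only 2-methoxyphenyl stands apart, with its steps to both others beyond the scatter. Nothing available alongside these binding numbers accounts for that difference.

Still open, going by these compounds, is whether the methoxy group of 2-methoxyphenyl or the six-membered ring itself carries the difference from thiophen-2-yl, a question that an unsubstituted phenyl ring at this place would address. Also open, on these data alone, is how a furan-2-yl ring, or a longer chain between the nitrogen and the aromatic ring, would read in this assay.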